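This account rests on a few compounds, and the source may have more. Where it says the series, first, only, none or still open, it means among the compounds named here.

Compound 1, `CC(C)(O/N=C(\C(=O)N[C@@H]1C(=O)N(S(=O)(=O)O)[C@@H]1CNC(=O)CN)c1csc(N)n1)C(=O)O`, gives 149 h in a physicochemical assay for metabolic stability, read by HPLC and mass spectrometry, in phosphate buffer, at 37 degrees C, at pH 7.4; on this read-out higher numbers stand for a longer-lived compound and lower numbers for a shorter-lived compound.
Compound 2, `CN(C[C@@H]1[C@H](NC(=O)/C(=N\OC(C)(C)C(=O)O)c2csc(N)n2)C(=O)N1S(=O)(=O)O)C(=O)CN`, gives 212 h in this assay.
Compound 3, `CC(C)(O/N=C(\C(=O)N[C@@H]1C(=O)N(S(=O)(=O)O)[C@@H]1CN1CCCCC1=O)c1csc(N)n1)C(=O)O`, gives 214 h in this assay.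

Compound 3 sits at the top of these three numbers, but the steps of a 1.4-fold higher number from compound 1 to compound 3 (0.16 log units; within the scatter) and a 1.0-fold higher number from compound 2 to compound 3 (0.00 log units; within the scatter) both stay inside the usual scatter, so the three compounds cannot truly be told apart in this assay.

Compound 4, `CC(C)(O/N=C(\C(=O)N[C@@H]1C(=O)N(S(=O)(=O)O)[C@@H]1CN1C[C@H](CN)OC1=O)c1csc(N)n1)C(=O)O`, differs from compound 3 in one place: 5-(aminomethyl)-2-oxo-1,3-oxazolidin-3-yl in place of 2-oxopiperidin-1-yl on a saturated chain carbon bound to a saturated ring carbon. The two steps that bear on this change are those that exchanged the same site for the 2-oxopiperidin-1-yl ring, a 1.4-fold higher number from compound 1 to compound 3 (0.16 log units; within the scatter) and a 1.0-fold higher number from compound 2 to compound 3 (0.00 log units; within the scatter), and each of them was too small to count. Going by the values given here, nothing measured so far shows this site moving the half-life beyond the scatter, so compound 4 is expected to show a 1.1-fold lower number from compound 3 to compound 4 (0.05 log units; within the scatter), a step of no real size in either direction. Compound 4 is therefore estimated at 190 h, with a range from 100 h to 350 h.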

Compound 4, half-life: > 37 h
Compound 4: no number, only a limit (the forecaster's own chance of this, stated with the estimate: 5%); the middle value is on the limit's open side.
By their numbers in this assay, from the lowest: compounds 1, 2 and 3 (each within the scatter of the next).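

Compound 4 gives > 37 h in this assay, which is a limit and not a number. Going by these compounds alone, no step from compound 1, compound 2 or compound 3 to compound 4 can be read. The compounds shown leave open whether the 5-(aminomethyl)-2-oxo-1,3-oxazolidin-3-yl group changes the half-life at all.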